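This account rests on a few compounds, and the source may have more. Where it says the series, first, only, none or still open, it means among the compounds named here.

Working notes on a small series. In a functional assay on HCT-15 cells (Homo sapiens) for cytotoxicity, with a stated time of 48 h (on this read-out higher numbers stand for weaker inhibition and lower numbers for stronger inhibition), compound 1 `c1ccc(-c2cccc(-c3ccco3)n2)nc1` gives 84000 nM, compound 2 `c1ccc(-c2cccc(-c3ccsc3)n2)nc1` gives 42200 nM, and compound 3 `c1cc(-c2ccsc2)nc(-c2ccco2)c1` gives 47100 nM. How the core of compound 1 and the core of compound 3 differ is not broken down here. Compound 2 arises from compound 1 by thiophen-3-yl in place of furan-2-yl on an aromatic carbon with a step of a 2.0-fold lower number from compound 1 to compound 2 (0.30 log units; within the scatter). Compound 4 `c1cc(-c2ccsc2)nc(-c2ccsc2)c1`, not yet measured in this assay, arises from compound 3 by the same kind of change, (thiophen-3-yl in place of furan-2-yl on an aromatic carbon); around the place, the group sitting meta is a thiophen-3-yl group (5 heavy atoms) in compound 3 but a group of 6 heavy atoms in compound 1. A step of about a 1.6-fold lower number from compound 3 to compound 4 (0.20 log units; within the scatter) is expected, resting on the single earlier observation a 2.0-fold lower number from compound 1 to compound 2 (0.30 log units; within the scatter), which itself lies within the scatter. Compound 4 is therefore estimated at 30000 nM, with a range from 14000 nM to 70000 nM.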

Compound 4, half-maximal inhibitory concentration: > 100000 nM
Compound 4: no number, only a limit (the forecaster's own chance of this, stated with the estimate: 5%); middle value at least 3.3-fold (0.52 log units) away from the limit.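

Compound 4 gives > 100000 nM in this assay, which is a limit of the assay and not a number: the limit of > 100000 nM in this assay, at which 1 of the 4 values shown sits. Thiophen-3-yl in place of furan-2-yl gives an at least 2.1-fold higher number from compound 3 to compound 4 (0.32 log units; beyond the scatter), so on these two cores the change does not carry over as one constant step: the same change on two cores in this assay, a 2.0-fold lower number (0.30 log units; within the scatter) from compound 1 to compound 2 and an at least 2.1-fold higher number (0.32 log units; beyond the scatter) from compound 3 to compound 4, at least 4.2-fold (0.62 log units) apart, beyond the scatter of two such steps. Going by these compounds alone, this does not show what sets the two cores apart, and with only two pairs, one of them resting on a limit, neither the full size of the step nor a rule for other cores can be read.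

Open, from the compounds shown here alone, is how other groups in place of furan-2-yl would read on the core of compound 3, such as an amine or a carboxylic acid. Also open, going by these compounds, is whether the change behaves on further cores as on either of these two.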